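A few compounds are considered here, and "the series" means these few. Any claim that something is new, unique, unknown or untested is made for them only; others in the source may bear on it.

Compound 1 `COc1cc(C(=O)c2cn(-c3cccc(Br)c3)cc2-c2ccccc2)cc(OC)c1OC` gives 78 nM in a functional assay on MCF7 cells (Homo sapiens) for cytotoxicity, read by MTT assay, with a stated time of 96 h; a lower number here means a stronger inhibitor, a higher number a weaker inhibitor.
Compound 2 `COc1cc(C(=O)c2cn(-c3ccccc3)cc2-c2ccccc2C)cc(OC)c1OC` gives 190 nM in this assay.

Of the two numbers recorded so far, compound 2 stands at the higher one; compound 1 gives a lower number, and the gap between them lies beyond the usual scatter of repeated measurements. Compound 3 `COc1ccccc1-c1cn(-c2ccccc2)cc1C(=O)c1cc(OC)c(OC)c(OC)c1` has not yet been measured in this assay. It differs from compound 2 in a single place: methoxy in place of methyl on an aromatic carbon. Going by the values given here, no pair of measured compounds differing in one place is available here, so there is no measured step to set this change against. On the two numbers alone, the step from compound 2 to compound 3 is expected to be small, if anything a modest move toward a lower number, and possibly none beyond the scatter, a 1.3-fold lower number from compound 2 to compound 3 (0.10 log units; within the scatter). Compound 3 is therefore estimated at 150 nM, with a range from 50 nM to 450 nM.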

Compound 3, half-maximal inhibitory concentration: 190 nM
Estimate against measurement, compound 3: 1.3-fold (0.10 log units) below, and the stated range covers the measured number.
By their numbers in this assay, from the lowest: compound 1; then compounds 2 and 3 (each within the scatter of the next).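

In this assay, replacing methyl with methoxy on this aromatic carbon, ortho to a large group, brings no change at the digits printed from compound 2 to compound 3 (within the scatter). Going by these compounds alone, this is the first measured step between compounds that differ in one place, and it shows that, at this position, methoxy can stand where methyl stood without the number moving beyond the scatter. Nothing given here explains why the two groups read alike.

As far as these compounds go, whether that holds for other groups at this position stays open, for instance an amine, a hydroxyl or a longer chain such as ethoxy. Compound 1 differs from compound 2 and from compound 3 in more than one place, so the effect of having no group at all at this position cannot be read from it.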